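The source may hold more compounds than are shown below. What is called first, only, known or untested is meant among the compounds shown, and "the series" means these compounds.

Compound 1 `CC(C)(C)n1ncc(OCc2nnc(-c3cc(F)c(F)cc3F)o2)c(Cl)c1=O` gives 75.7 ug/mL in a functional assay on the whole organism for inhibition, with Mythimna separata as the target, with a stated time of 5 days; a higher number here means that more compound is needed for the effect, a lower number that less compound is needed. Compound 2 `CC(C)(C)n1ncc(OCc2nnc(-c3ccco3)o2)c(Cl)c1=O` gives only a limit in this assay, > 300 ug/mL.

Compound 2 therefore stands at the limit of this assay rather than at a measured number, as noted in the limit of > 300 ug/mL in this assay, at which 1 of the 2 values shown sits. Among the compounds with values here, the one measured step, an at least 3.9-fold higher number from compound 1 to compound 2 (0.59 log units; beyond the scatter), shows that exchanging a fluorinated phenyl for a furan ring made this assay report only a limit. Compound 3 `CC(C)(C)n1ncc(OCc2nnc(-c3cc(F)c(Cl)cc3Cl)o2)c(Cl)c1=O` reverses that kind of change: 2,4-dichloro-5-fluorophenyl in place of furan-2-yl on an aromatic carbon. Since the new group is again a halogenated phenyl, close in kind to the ring of compound 1, the step from compound 2 to compound 3 is expected to run in the opposite direction to the measured one, toward a lower number, and by a size of the same order. Compound 3 is accordingly estimated at 70 ug/mL in this assay, with a plausible range from 25 ug/mL to 250 ug/mL, corresponding to an expected step of an at least 4.2-fold lower number from compound 2 to compound 3 (0.63 log units; beyond the scatter).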

Compound 3, half-maximal effective concentration: 23.1 ug/mL
The estimate for compound 3 lay 3.0-fold (0.48 log units) above the measured number; measured number outside the range, below it.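

Putting a halogenated phenyl back at this position, on the aromatic carbon of the five-membered ring, restores a measurable number in this assay, with an at least 12-fold lower number from compound 2 to compound 3 (1.11 log units; beyond the scatter). What is new is that halogenated phenyl rings are not interchangeable here: 2,4-dichloro-5-fluorophenyl in place of 2,4,5-trifluorophenyl gives a 3.3-fold lower number from compound 1 to compound 3 (0.52 log units; beyond the scatter), so the choice of halogens on the ring affects the result, not only the presence of a phenyl. The true size of the step from the furan compound remains unknown, because compound 2 has only a limit: the limit of > 300 ug/mL in this assay, at which 1 of the 3 values shown sits.

It remains open which of the chlorine atoms of compound 3 accounts for its lower number, as the compounds shown do not separate them. As far as these compounds go, it is also open how a phenyl ring carrying a methoxy group or a nitrile, or a saturated cyclohexyl ring, would fare at this position.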